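The source may hold more compounds than are shown below. What is called first, only, known or untested is meant among the compounds shown, and "the series" means these compounds.

Measured so far:
compound 1 `N#CC1=C(N)Oc2c(c3nc4ccccc4nc3c3ccccc23)C12C(=O)N(Cc1cnnn1-c1ccc([N+](=O)[O-])cc1)c1ccccc12` — > 50000 nM
compound 2 `Cc1ccc(C)c(-n2nncc2CN2C(=O)C3(C(C#N)=C(N)Oc4c3c3nc5ccccc5nc3c3ccccc43)c3ccccc32)c1` — > 50000 nM
compound 3 `Cc1ccccc1-n1nncc1CN1C(=O)C2(C(C#N)=C(N)Oc3c(N)cc4nc5ccccc5nc4c32)c2ccccc21` — > 50000 nM

All three values come from a functional assay on HCT-116 cells (Homo sapiens) for antiproliferative activity, read by MTT assay, with a stated time of 48 h; a lower number here means a stronger inhibitor, a higher number a weaker inhibitor. For compound 1 the value > 50000 nM is a limit of this assay, not a number. For compound 2 the value > 50000 nM is likewise a limit. For compound 3 the value > 50000 nM is also a limit, so compound 3 stands at the edge of what this assay resolves, with no number of its own; its two companions stand at the same edge (the limit of > 50000 nM in this assay, at which 3 of the 3 values shown sit).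

For the measured compounds named here, the only step between two measured compounds that differ in one place is a step that the two limits leave unreadable from compound 1 to compound 2, 2,5-dimethylphenyl in place of 4-nitrophenyl on an aromatic nitrogen; its size cannot be read, since both ends are limits.

Compound 4 `Cc1ccc(-n2nncc2CN2C(=O)C3(C(C#N)=C(N)Oc4c(N)cc5nc6ccccc6nc5c43)c3ccccc32)cc1C` differs from compound 3 by 3,4-dimethylphenyl in place of 2-methylphenyl on an aromatic nitrogen. The step that bears on it, from compound 1 to compound 2, is a change of the aryl group on the same aromatic nitrogen, and it gave no readable size. With every shown value sitting at the limit (the limit of > 50000 nM in this assay, at which 3 of the 3 values shown sit), no direction can be drawn for this step in this assay, and the expectation is that compound 4 also returns a limit rather than a number.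

Compound 4 is therefore expected at 60000 nM in this assay, within 25000 nM to 150000 nM. The expected step from compound 3 to compound 4 is a step that the limit leaves unreadable from compound 3 to compound 4, which is within the scatter.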

Compound 4, half-maximal inhibitory concentration: > 50000 nM
Compound 4 gave a limit, no number; the forecaster's own chance of this, stated with the estimate: 85%; the middle value does not contradict the limit.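

No new step can be read: compound 3 and compound 4 both stand at a limit, not a number, so 3,4-dimethylphenyl in place of 2-methylphenyl has no readable size in this assay. The compounds shown leave open whether any aryl group on this aromatic nitrogen, or any change to the shared core, gives a measurable value in this assay.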